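A few compounds are considered here, and "the series" means these few. Any claim that something is new, unique, unknown or untested is made for them only; others in the source may bear on it.

Working notes on the series. Three members have so far been run in an ADME assay on HEK-293T cells (Homo sapiens) for cytotoxicity, read by CCK-8 assay, with a stated time of 48 h; a lower number here means a stronger inhibitor, a higher number a weaker inhibitor. For the measured compounds named here, compound 1 `O=[N+]([O-])c1ccc(NC(=S)NCCNS(=O)(=O)c2ccc(-c3ccccc3OCc3ccccc3)s2)cc1` gives 8900 nM in this assay, the only number among the three. Compound 2 `O=C(NCCNS(=O)(=O)c1ccc(-c2ccccc2OCc2cccc(O)c2)s1)Nc1cc(Cl)cc(Cl)c1` returns only a limit, > 20000 nM. Compound 3 `Cc1cc(C)cc(NC(=O)NCCNS(=O)(=O)c2ccc(-c3ccccc3OCc3cccc(O)c3)s2)c1` likewise returns only a limit, > 20000 nM. Going by the values given here, the single one-point step available, a step that the two limits leave unreadable from compound 2 to compound 3, therefore cannot be read, since both of its ends sit at the limit of > 20000 nM in this assay, at which 2 of the 3 values shown sit. Compound 3 thus stands at the edge of what this assay resolves: it cannot be ranked against compound 2, and only compound 1 lies inside the measured range.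

Compound 4 `O=[N+]([O-])c1ccc(NC(=S)NCCNS(=O)(=O)c2ccc(-c3ccccc3OCc3cccc(O)c3)s2)cc1` is the next member to be measured. Relative to compound 3 it carries a group of 12 heavy atoms (7 carbon, 2 nitrogen, 2 oxygen, 1 sulfur; one six-membered aromatic ring of carbon only) in place of a group of 11 heavy atoms (9 carbon, 1 nitrogen, 1 oxygen; one six-membered aromatic ring of carbon only), on an amine nitrogen. Among the compounds with values here, no measured step touches this exchange; the only step recorded, from compound 2 to compound 3, is unreadable and concerns a different position, so it supplies neither size nor direction to carry over. The entering group is also present in compound 1, which gave 8900 nM in this assay. On that basis the expected value for compound 4 is 10000 nM, with a range from 4000 nM to 20000 nM. The step this implies, an at least 2.0-fold lower number from compound 3 to compound 4 (0.30 log units; that floor lies within the scatter), is an estimate and may well remain unreadable if the limit recurs.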

Compound 4, half-maximal inhibitory concentration: > 20000 nM
Compound 4 was reported as a limit; the forecaster's own chance of this, stated with the estimate: 40%; at least 2.0-fold (0.30 log units) between middle value and limit.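

In this assay, for the compounds shown here, the hydroxy in place of hydrogen on an aromatic carbon gives the first readable step: an at least 2.2-fold higher number from compound 1 to compound 4 (0.35 log units; beyond the scatter). On these data alone, compound 4 gives > 20000 nM, which is a limit and not a number, so the true size of this step stays open on its upper side. The steps linking compound 4 to compound 2 and to compound 3 cannot be read, so exchanging the (3,5-dimethylphenyl)carbamoyl group on the amine nitrogen for the group in compound 4 shows no size or direction, with both ends of each step at the same limit: the limit of > 20000 nM in this assay, at which 3 of the 4 values shown sit.

Going by these compounds alone, compound 1 is the only member without the hydroxy, so it remains open whether the same change would move the number with the urea groups of compound 2 and compound 3. As far as these compounds go, it is also open whether a methoxy, an amine or a carboxylic acid in place of that hydroxy would leave the number inside the measured range of this assay or at the limit.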